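The source may hold more compounds than are shown below. What is called first, only, known or untested is meant among the compounds shown, and "the series" means these compounds.

Going by the values given here, compound 1 `CC(CCNC(=O)c1c(Cl)cncc1Cl)N1CCC(C(Oc2ccccc2)c2ccc(C(F)(F)F)cc2)CC1` is the only member of the series with a number in an ADME assay on PBMC cells (Homo sapiens) for cytotoxicity; on this read-out lower numbers stand for higher toxicity in this test and higher numbers for lower toxicity in this test: compound 1 gives 6800 nM. Compound 2 `CCO/N=C(/c1ccc(Br)cc1)C1CCN(C(C)CCNC(=O)c2c(C)cc[n+]([O-])c2C)CC1` reaches only a limit of the assay in this assay, > 177000 nM. Compound 3 `CCO/N=C(/c1ccc(Br)cc1)C1CCN(C(C)CCN(C)C(=O)c2c(C)cc[n+]([O-])c2C)CC1` likewise reaches only a limit in this assay, > 182000 nM. The step from compound 2 to compound 3, methyl in place of hydrogen on an amide-type nitrogen, is thus a step that the two limits leave unreadable from compound 2 to compound 3; the two limits the limit of > 177000 nM in this assay, at which 1 of the 3 values shown sits, and the limit of > 182000 nM in this assay, at which 1 of the 3 values shown sits, leave its size unknown.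

Compound 4 `CC(CCNC(=O)c1c(Cl)cncc1Cl)N1CCC(C(Oc2cccc(C(F)(F)F)c2)c2ccc(C(F)(F)F)cc2)CC1` differs from compound 1 in one place: trifluoromethyl in place of hydrogen on an aromatic carbon. Cut one bond further out, the phenoxy of compound 1 becomes 3-(trifluoromethyl)phenoxy. Among the compounds with values here, no measured step in this assay touches this ring or a trifluoromethyl group, and the one measured step is unreadable and sits on another part of a different core. The expectation for compound 4 therefore rests on compound 1 alone, and a step of a 1.2-fold lower number from compound 1 to compound 4 (0.09 log units; within the scatter), within the usual scatter, is expected. Compound 4 is expected to give 5500 nM in this assay, between 2000 nM and 15000 nM.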

Compound 4, half-maximal cytotoxic concentration: 7000 nM
Beside the measured number, compound 4's estimate is 1.3-fold (0.10 log units) below it; the range from low to high includes it.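

In this assay, trifluoromethyl in place of hydrogen on an aromatic carbon of the phenoxy group gives a 1.0-fold higher number from compound 1 to compound 4 (0.01 log units; within the scatter), so compound 1 and compound 4 read alike at this position. Going by these compounds alone, this is the first readable step: the step between compound 2 and compound 3 cannot be read, and it lies on another part of a different core, so only this pair speaks to the phenoxy group. Nothing shown bears on why this change leaves the read-out within the scatter.

On these data alone, it remains open whether a carboxylic acid or a primary amine on this ring would read the same way as trifluoromethyl. Also open, as far as these compounds go, is whether trifluoromethyl at another place on this ring, or on the other aromatic ring of the shared core, would do so.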